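Neopentyl in place of methyl on a scaffold without measured activity

The source may hold more compounds than are shown below. What is called first, only, known or untested is meant among the compounds shown, and "the series" means these compounds.

Compound 1, `CC(C)(C)Cn1cc2c(Cl)nc(NC(=O)c3ccccc3)nc2n1`, in a functional assay on CHO cells for antagonist activity at adenosine receptor A2b (Homo sapiens), read by 33P incorporation, with a stated time of 20 min, in the presence of a further agent that is not named here (on this read-out lower numbers stand for stronger inhibition and higher numbers for weaker inhibition), gives >= 10000 nM, a limit of the assay.
Compound 2, `Cn1cc2c(Cl)nc(NC(=O)c3ccc(C(F)(F)F)cc3)nc2n1`, in this assay gives > 20000 nM, likewise a limit.

Compound 2 therefore stands at a limit rather than at a number, and compound 1 stands at a limit as well (the limit of > 20000 nM in this assay, at which 1 of the 2 values shown sits, (the limit of >= 10000 nM in this assay, at which 1 of the 2 values shown sits)). Compound 3, `CC(C)(C)Cn1cc2c(Cl)nc(NC(=O)c3ccc(C(F)(F)F)cc3)nc2n1`, differs from compound 2 by tert-butyl in place of hydrogen on a saturated chain carbon bound to an aromatic nitrogen. Compound 1 already carries the same tert-butyl-bearing chain and sits at a limit, so in this assay no step beyond the scatter is expected, and a limit is again the likeliest outcome. Compound 3 is thus expected to give 20000 nM, between 5000 nM and 60000 nM, an expected step of a number no higher from compound 2 to compound 3 (the limit leaves the size open).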

Compound 3, inhibition constant: > 20000 nM
Compound 3 gave a limit, no number; the forecaster's own chance of this, stated with the estimate: 85%; the middle value sits exactly at the limit.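

For the compounds shown here, compound 3 sits at a limit in this assay, as do compound 1 and compound 2, so no step among them can be read. The compounds shown leave open what neopentyl in place of methyl, or trifluoromethyl in place of hydrogen, changes.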